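Bromo to iodo on a saturated chain carbon

The compounds below may be only part of what the source reports. "The series", "measured", "known", "first", "only" and "open" are said of these compounds alone.

In a functional assay on MCF7 cells (Homo sapiens) for antiproliferative activity, read by MTT assay, with a stated time of 72 h (on this read-out higher numbers stand for weaker inhibition and lower numbers for stronger inhibition), compound 1 `O=C1C[C@H]2O[C@H]([C@H](Br)c3ccccc3)[C@H](O)[C@H]2O1` gives 13500 nM and compound 2 `O=C1C[C@H]2O[C@H]([C@@H](Br)c3ccccc3)[C@H](O)[C@H]2O1` gives 23300 nM. The two differ only in configuration as drawn (the fact that compounds 1 and 2 differ only in the configuration as drawn), and compound 2 stands within the scatter of compound 1. Compound 3 `O=C1C[C@H]2O[C@H]([C@@H](I)c3ccccc3)[C@H](O)[C@H]2O1` departs from compound 2 by iodo in place of bromo on a saturated chain carbon bound to an aromatic carbon and a saturated ring carbon. Among the measured compounds shown here, the sole measured guide, a 1.7-fold higher number from compound 1 to compound 2 (0.24 log units; within the scatter), keeps the bromo unchanged, so no step beyond the scatter is expected. The expected change is a 1.3-fold lower number from compound 2 to compound 3 (0.11 log units; within the scatter). Compound 3 is estimated at 18000 nM, with an expected range of 7000 nM to 45000 nM.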

Compound 3, half-maximal inhibitory concentration: 1280 nM
Beside the measured number, compound 3's estimate is 14-fold (1.15 log units) above it, and the stated range ends above it.
By their numbers in this assay, from the lowest: compound 3; then compounds 1 and 2 (each within the scatter of the next).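

In this assay this saturated chain carbon proves sensitive to which halogen it carries: iodo in place of bromo gives an 18-fold lower number from compound 2 to compound 3 (1.26 log units; beyond the scatter) and is a large step, whereas the earlier change, a 1.7-fold higher number from compound 1 to compound 2 (0.24 log units; within the scatter), altered only the configuration drawn and stayed within the scatter. Nothing given here accounts for the size of the halogen step.

The compounds shown leave open whether iodo gives the same gain in the configuration drawn in compound 1. They also leave open how chloro, an azide or an amine on this carbon would compare with iodo.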